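Benzyl Swapped for 2-Methoxyphenyl on the Urea Nitrogen

The compounds below may be only part of what the source reports. "The series", "measured", "known", "first", "only" and "open" are said of these compounds alone.

Compound 1 `CC(=O)Nc1nn(-c2ccccc2)c(=O)c2ccccc12` gives 52% in an assay on CHO cells for displacement of a labelled ligand from adenosine receptor A1 (Homo sapiens), tested at 10 uM; a higher number here means more inhibition at the concentration tested (going by the name of the read-out), a lower number less inhibition.
Compound 2 `O=C(NCc1ccccc1)Nc1nn(-c2ccccc2)c(=O)c2ccccc12` gives 20% in this assay.

Compound 2 stands lowest of the two numbers shown in this assay; its nearest neighbour is compound 1, whose number is higher by a step beyond the scatter. Within the data shown here, the only measured step, a number 32 percentage points lower from compound 1 to compound 2 (beyond the scatter), came from putting benzylamino in place of methyl on the carbonyl carbon, and it was large and downward. Compound 3 `COc1ccccc1NC(=O)Nc1nn(-c2ccccc2)c(=O)c2ccccc12` keeps that benzylamino-derived urea and changes it one bond further out: 2-methoxyphenyl in place of benzyl on an amide-type nitrogen. Among the measured compounds shown here, no measured step touches this place, so the measured step gives only a loose guide that groups on this side of the carbonyl can move the number strongly. For compound 3 the expected step is a number 10 percentage points higher from compound 2 to compound 3 (within the scatter), a modest rise that may still lie within the scatter. Compound 3 is therefore estimated at 30%, with a range from 8% to 58%.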

Compound 3, a percentage reported as inhibition, at one concentration (the size of the read-out at that concentration, not a potency): 0%
Compound 3: the middle estimate sits 30 percentage points above what was measured; measured number below the stated range.
By their numbers in this assay, from the lowest: compound 3; then compound 2; then compound 1.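

In this assay, 2-methoxyphenyl in place of benzyl on the amide-type nitrogen gives a number 20 percentage points lower from compound 2 to compound 3 (beyond the scatter), so the number depends on which group sits on this nitrogen, not only on methyl having been replaced. Set against the methyl compound, (2-methoxyphenyl)amino in place of methyl on the carbonyl carbon gives a number 52 percentage points lower from compound 1 to compound 3 (beyond the scatter), so both replacements for methyl shown here lower the number. Nothing available explains why the number falls with either change.

The change swaps benzyl for a ring that carries a methoxy group and is bonded straight to the nitrogen, so plain phenyl and 2-methoxybenzyl would be needed to tell these two features apart. Going by these compounds, whether a small chain such as ethyl on this nitrogen would restore the number also stays open.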